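A large aryl group gives way to methyl

This account rests on a few compounds, and the source may have more. Where it says the series, first, only, none or still open, it means among the compounds named here.

Values in a functional assay on MCF7 cells (Homo sapiens) for antiproliferative activity, read by MTT assay, with a stated time of 48 h; on this read-out higher numbers stand for weaker inhibition and lower numbers for stronger inhibition:
Compound 1 `CCN(CC)Cc1ccc2c(c1O)-c1ccc(cc1O)CCc1ccc(O)c(c1)Oc1ccc(cc1)CC2`: 7590 nM
Compound 2 `Oc1ccc2cc1Oc1ccc(cc1)CCc1ccc(CN3CCCC3)c(O)c1-c1ccc(cc1O)CC2`: 2410 nM
Compound 3 `COc1ccc(N2CCN(Cc3ccc4c(c3O)-c3ccc(cc3O)CCc3ccc(O)c(c3)Oc3ccc(cc3)CC4)CC2)cc1`: > 20000 nM (a limit)

Compound 3 gives no number, and it sits at the limit of > 20000 nM in this assay, at which 1 of the 3 values shown sits. Compound 4 `CN1CCN(Cc2ccc3c(c2O)-c2ccc(cc2O)CCc2ccc(O)c(c2)Oc2ccc(cc2)CC3)CC1` has not yet been measured. It differs from compound 3 by methyl in place of 4-methoxyphenyl on an amine nitrogen in a ring, with methyl in place of 4-methoxyphenyl on an amine nitrogen in a ring.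

For the measured compounds named here, no measured step makes this exchange. Going by the values given here, the only step available is on another amine, where pyrrolidin-1-yl replaces diethylamino: a 3.1-fold lower number from compound 1 to compound 2 (0.50 log units; beyond the scatter). That step is modest but beyond the scatter, and it shows that the amine group can shift the read-out. Compound 4 no longer carries the aromatic ring of the leaving group, so it is expected to fall closer to compound 1, which gives 7590 nM, than to compound 3.

As far as these compounds go, a step toward a lower number is therefore expected, and its exact size stays open while compound 3 has only a limit. The estimated step is an at least 3.0-fold lower number from compound 3 to compound 4 (0.48 log units; beyond the scatter). For compound 4 the estimated value is 6500 nM, with an expected range of 2500 nM to 16000 nM.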

Compound 4, half-maximal inhibitory concentration: 6020 nM
Compound 4: middle estimate off by 1.1-fold (0.03 log units), on the high side; the range from low to high includes it.
By their numbers in this assay, from the lowest: compound 2; then compounds 4 and 1 (each within the scatter of the next). At a limit, above all of these: compound 3.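

In this assay, compound 3 gives only a limit, so the change can be read only as a minimum: the limit of > 20000 nM in this assay, at which 1 of the 4 values shown sits.

Even so, methyl in place of 4-methoxyphenyl on the amine nitrogen in the ring gives an at least 3.3-fold lower number from compound 3 to compound 4 (0.52 log units; beyond the scatter), the first evidence that the group on this nitrogen can move the read-out. With methyl there, the 4-methylpiperazin-1-yl group compares with diethylamino as a 1.3-fold lower number from compound 1 to compound 4 (0.10 log units; within the scatter), and with pyrrolidin-1-yl as a 2.5-fold higher number from compound 2 to compound 4 (0.40 log units; beyond the scatter), so compound 2 keeps the lowest number of the series.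

The compounds shown leave open whether the aromatic ring or its methoxy accounts for the difference, which an unsubstituted phenyl on that nitrogen would help separate. They also leave open how a piperidin-1-yl or morpholin-4-yl group would compare with pyrrolidin-1-yl.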